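The source may hold more compounds than are shown below. What is called first, only, known or untested is meant among the compounds shown, and "the series" means these compounds.

Measured so far in an ADME assay on the whole organism for pharmacokinetics, with Rattus norvegicus as the target, with a stated time of 6 h, at a dose of 10 mg/kg by the oral route; a higher number here means more compound in the circulation at the dose given, a lower number less compound in the circulation:

compound 1 `Cc1cn2c(-c3cn[nH]c3)cnc2c(Nc2cc(Cc3ncccn3)ns2)n1`: 701 ng.h/mL
compound 2 `Cc1cn2c(-c3cn[nH]c3)cnc2c(Nc2cc(Cc3ncccc3C)ns2)n1`: 644 ng.h/mL
compound 3 `Cc1cn2c(-c3cn[nH]c3)cnc2c(Nc2cc(Cc3cccc(F)n3)ns2)n1`: 2970 ng.h/mL

Compound 3 gives the highest of the three numbers. The step of a 4.2-fold higher number from compound 1 to compound 3 (0.63 log units; beyond the scatter) and the step of a 4.6-fold higher number from compound 2 to compound 3 (0.66 log units; beyond the scatter) are both beyond the scatter, while the step of a 1.1-fold lower number from compound 1 to compound 2 (0.04 log units; within the scatter) is within it, so compound 1 and compound 2 are not ordered against each other, and compound 3 stands apart from both.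

Compound 4 `Cc1cn2c(-c3cn[nH]c3)cnc2c(Nc2cc(Cc3cccc(C(=O)N4CCCCC4)n3)ns2)n1` is the next member. It differs from compound 3 in one place: (piperidin-1-yl)carbonyl in place of fluoro on an aromatic carbon.

Among the compounds with values here, none of the measured steps covers this change. The three measured steps all exchange the whole aromatic group on the saturated chain carbon, and the only one bearing the fluoro on the ring next to the ring nitrogen is compound 3, whose number is the high one. Within the data shown here, compound 4 keeps that ring but carries the piperidinylcarbonyl in its place, and no measured pair shows what that does in this assay. The high number of compound 3 is therefore not secured for compound 4; the expectation is a step of a 3.3-fold lower number from compound 3 to compound 4 (0.52 log units; beyond the scatter), a lower number, with wide uncertainty.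

Compound 4 is expected to give about 900 ng.h/mL, in the range 250 ng.h/mL to 3500 ng.h/mL.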

Compound 4, area under the concentration-time curve: 50 ng.h/mL
Beside the measured number, compound 4's estimate is 18-fold (1.26 log units) above it; measured number below the stated range.
By their numbers in this assay, from the lowest: compound 4; then compounds 2 and 1 (each within the scatter of the next); then compound 3.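

Up to this point the changes exchanged the whole aromatic group on the saturated chain carbon. Here the six-membered aromatic ring stays and only the group on its aromatic carbon next to the ring nitrogen changes, yet this assay shows a 59-fold lower number from compound 3 to compound 4 (1.77 log units; beyond the scatter), the largest step in the series so far, so the high number of compound 3 belongs to 6-fluoropyridin-2-yl and not to the ring alone. The change is also a large one in size, with fluoro, a single heavy atom, giving way to (piperidin-1-yl)carbonyl, which has 8 heavy atoms, a six-membered non-aromatic ring and a hydrogen-bond acceptor. Nothing available on these compounds bears on what lies behind this step.

The compounds shown leave open whether the loss follows the carbonyl or the piperidine ring, a question that a dimethylamide, a primary carboxamide, a methoxy group or a plain methyl at this position would help to settle. Also open, from the compounds shown here alone, is whether the area under the curve falls through uptake or through clearance, which this single read-out cannot separate.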